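The compounds below may be only part of what the source reports. "The series", "measured", "known", "first", "only" and "open" are said of these compounds alone.

Compound 1 `O=c1[nH]cc(S(=O)(=O)Nc2ccccc2-c2cn(-c3ccccc3)nn2)c(=O)[nH]1`, compound 2 `Cc1ccc(-n2cc(-c3ccccc3NS(=O)(=O)c3c[nH]c(=O)[nH]c3=O)nn2)cc1` and compound 3 `O=c1[nH]cc(S(=O)(=O)Nc2ccccc2-c2cn(-c3ccccc3Cl)nn2)c(=O)[nH]1` share one core and differ only in the ring attached to an aromatic nitrogen. In a functional assay on OVCAR-3 cells (Homo sapiens) for antiproliferative activity, read by MTT assay, with a stated time of 24 h (on this read-out higher numbers stand for weaker inhibition and lower numbers for stronger inhibition), compound 1 gives 6650 nM, compound 2 gives 2190 nM, and compound 3 gives 3170 nM. Compound 2 thus has the lowest number of the three, though its gap to compound 3 lies within the scatter a 1.4-fold higher number from compound 2 to compound 3 (0.16 log units; within the scatter), while its gap to compound 1 lies beyond it a 3.0-fold lower number from compound 1 to compound 2 (0.48 log units; beyond the scatter). Compound 4 `O=c1[nH]cc(S(=O)(=O)Nc2ccccc2-c2cn(-c3cccc(Cl)c3)nn2)c(=O)[nH]1` has not yet been measured. It differs from compound 2 by 3-chlorophenyl in place of 4-methylphenyl on an aromatic nitrogen. Among the compounds with values here, two measured steps bear on this. Adding a chloro in place of hydrogen gave a 2.1-fold lower number from compound 1 to compound 3 (0.32 log units; beyond the scatter), a modest change, and swapping the 4-methylphenyl for a 2-chlorophenyl gave a step within the scatter. A chlorine on the ring at a different position is therefore expected to leave the number close to that of compound 2, with no step beyond the scatter. For compound 4 the expected value in this assay is 2600 nM, within a range of 1200 nM to 5600 nM, an estimated step of a 1.2-fold higher number from compound 2 to compound 4 (0.07 log units; within the scatter).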

Compound 4, half-maximal inhibitory concentration: 2180 nM
For compound 4 the middle estimate is 1.2-fold (0.08 log units) above the measured one; low and high end bracket the measured number.
By their numbers in this assay, from the lowest: compounds 4, 2 and 3 (each within the scatter of the next); then compound 1.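

Shifting the chlorine on the ring in this assay gives a 1.5-fold lower number from compound 3 to compound 4 (0.16 log units; within the scatter) and so does not separate the 2-chlorophenyl from the 3-chlorophenyl, while exchanging the 4-methylphenyl for the 3-chlorophenyl gives a 1.0-fold lower number from compound 2 to compound 4 (0.00 log units; within the scatter) and does not separate those two either. The gain over the plain phenyl ring also appears with the chlorine in this new place, as a 3.1-fold lower number from compound 1 to compound 4 (0.48 log units; beyond the scatter) shows, so all three substituted rings stand apart from compound 1 while staying within the scatter of one another. No measurement offers an explanation for this similarity.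

Still open, on these data alone, is whether an amine, a carboxylic acid or a methoxy group on this ring would behave like the methyl and the chlorine. A 4-chlorophenyl would show whether the chlorine also fits this pattern in the place the methyl occupies in compound 2.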